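Difluorophenyl regiochemistry on the cyclopropane amide series

This account rests on a few compounds, and the source may have more. Where it says the series, first, only, none or still open, it means among the compounds named here.

Compound 1 `CC[C@H](C)[C@H](N)CN(C(=O)[C@@H]1C[C@H]1c1cccc(C#N)c1)c1ccc(-c2ccccc2)cc1` gives 1600 nM in a functional assay for agonist activity at G protein-coupled receptor 88 (Homo sapiens), read by HTRF and cAMP accumulation; on this read-out higher numbers stand for an effect only at larger amounts of compound and lower numbers for an effect already at smaller amounts. For the measured compounds named here, compound 2 `CC[C@H](C)[C@H](N)CN(C(=O)[C@@H]1C[C@H]1c1cc(F)cc(F)c1)c1ccc(-c2ccccc2)cc1` gives 960 nM, the lowest of the two numbers so far, though a 1.7-fold lower number from compound 1 to compound 2 (0.22 log units; within the scatter) stays within the scatter, so neither compound can be called the more potent. Compound 3 `CC[C@H](C)[C@H](N)CN(C(=O)[C@@H]1C[C@H]1c1ccc(F)c(F)c1)c1ccc(-c2ccccc2)cc1` carries the change (3,4-difluorophenyl in place of 3,5-difluorophenyl on a saturated ring carbon). Going by the values given here, the only measured step at this ring is a 1.7-fold lower number from compound 1 to compound 2 (0.22 log units; within the scatter), itself within the scatter, and no measured pair separates the two difluoro patterns. Compound 3 is therefore expected near 1000 nM (range 400 nM to 2500 nM), with a 1.0-fold higher number from compound 2 to compound 3 (0.02 log units; within the scatter) expected to remain within the scatter.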

Compound 3, half-maximal effective concentration: 720 nM
Compound 3: the middle estimate sits 1.4-fold (0.14 log units) above what was measured, and the stated range covers the measured number.
By their numbers in this assay, from the lowest: compounds 3, 2 and 1 (each within the scatter of the next, the first and the last beyond it).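

In this assay the two difluoro patterns stay unresolved, with a 1.3-fold lower number from compound 2 to compound 3 (0.12 log units; within the scatter). For the compounds shown here, the 3,4-difluorophenyl group gives the first step at this position that clears the scatter, though only modestly, with a 2.2-fold lower number from compound 1 to compound 3 (0.35 log units; beyond the scatter), whereas the 3,5-difluorophenyl group stays within the scatter of 3-cyanophenyl. Nothing available explains either step. As far as these compounds go, it remains open whether a single fluorine, a methoxy or a trifluoromethyl on the phenyl would read differently from the difluoro patterns. Also open, from the compounds shown here alone, is whether the small gain from 3,4-difluorophenyl carries over to other substituents on the shared core.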